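This account rests on a few compounds, and the source may have more. Where it says the series, first, only, none or still open, it means among the compounds named here.

Measured so far in a functional assay on EL4 cells (Mus musculus) for inhibition, tested at 100 uM; on this read-out higher numbers stand for more inhibition at the one concentration tested (going by the name of the read-out) and lower numbers for less inhibition:
compound 1 `CCNc1nccc2c1ncn2C1O[C@H](CO)[C@@H](O)[C@H]1O` gives 8%
compound 2 `CC1OC(n2cnc3c(N)nccc32)CC1O` gives 25%
compound 3 `c1ccc(CSc2[nH]ccc3ncnc2-3)cc1` gives 20%

Compound 1 stands lowest of the three numbers in this assay. Its nearest neighbour is compound 3, whose number lies higher by more than the usual scatter; compound 2 stands further off, also beyond the scatter. For the measured compounds named here, no pair among the measured compounds differs in only one place, so no single-step comparison is available.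

Compound 4 `CCCCCCNc1nccc2c1ncn2C1O[C@H](CO)[C@@H](O)[C@H]1O` remains to be measured. It differs from compound 1 as follows: butyl in place of hydrogen on a saturated chain carbon, two bonds along the chain from a nitrogen on an aromatic ring. Nothing measured here shows what a butyl added at such a place does to the read-out. A modest step, if any, is expected: from compound 1 to compound 4 the estimated change is a number 7 percentage points higher from compound 1 to compound 4 (within the scatter), which may not exceed the scatter. For compound 4 the expected value in this assay is 15%, with a range from 0% to 35%.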

Compound 4, a percentage reported as inhibition, at one concentration (the size of the read-out at that concentration, not a potency): 14%
Beside the measured number, compound 4's estimate is 1 percentage points above it; measured number inside the range.
By their numbers in this assay, from the lowest: compounds 1, 4, 3 and 2 (each within the scatter of the next, the first and the last beyond it).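

For the compounds shown here, this is the only comparison that differs in one place: in this assay, the step for butyl in place of hydrogen on a saturated chain carbon, two bonds along the chain from a nitrogen on an aromatic ring, reads a number 6 percentage points higher from compound 1 to compound 4 (within the scatter) and so gives no clear change. Going from ethylamino to hexylamino at this position therefore leaves the read-out within the usual scatter. Nothing available accounts for this result.

On these data alone, whether a longer chain than hexylamino would stay within the scatter remains open. So does the effect of an amine or a carboxylic acid carried on the chain.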